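Replacing the aromatic nitrogen aryl group with tert-butyl

The compounds below may be only part of what the source reports. "The series", "measured", "known", "first", "only" and "open" are said of these compounds alone.

Three ureas built on a shared pyrazole core were examined in an assay on isolated protein for inhibition of STE20-like serine/threonine-protein kinase (Homo sapiens), read by thermal shift assay, tested at 10 uM; a lower number here means that the compound stabilises the target less, a higher number that the compound stabilises the target more against heat. Within the data shown here, compound 1 `CC(C)(C)c1cc(NC(=O)Nc2ccc(F)cc2)n(-c2ccccc2)n1` gives 7.4 degrees C. Compound 2 `Cc1ccc(F)cc1NC(=O)Nc1cc(C(C)(C)C)nn1-c1ccccc1` gives 6 degrees C, and the step of a number 1.4 degrees C lower from compound 1 to compound 2 (beyond the scatter) is the only one-point change measured among them. Compound 3 `Cc1ccc(-n2nc(C(C)(C)C)cc2NC(=O)Nc2cc(C(F)(F)F)cc(C(F)(F)F)c2)cc1` gives 0 degrees C, the lowest of the three numbers; compound 2 sits above it by a margin beyond the scatter, and compound 1 sits higher still. Compound 3 differs from compounds 1 and 2 in more than one place, so its values beside theirs show only that it stabilises the target far less; no single step accounts for the gap.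

Compound 4 `CC(C)(C)c1cc(NC(=O)Nc2cc(C(F)(F)F)cc(C(F)(F)F)c2)n(C(C)(C)C)n1` is made from compound 3 by the change (tert-butyl in place of 4-methylphenyl on an aromatic nitrogen). Among the measured compounds shown here, no measured step touches this aromatic nitrogen position, and the one measured step, from compound 1 to compound 2, concerns the amide-type nitrogen instead and was modest. With nothing that bears directly on the change, the expectation is anchored on the low starting point of compound 3. Compound 4 is therefore expected to give 1.5 degrees C, with a range from -0.5 degrees C to 4 degrees C, a step of a number 1.5 degrees C higher from compound 3 to compound 4 (beyond the scatter) that is expected to stay close to the scatter.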

Compound 4, shift of the target's melting temperature: -0.2 degrees C
Compound 4: middle estimate off by 1.7 degrees C, on the high side, within the range that was stated.
By their numbers in this assay, from the lowest: compounds 4 and 3 (each within the scatter of the next); then compound 2; then compound 1.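

In this assay, among these compounds, the one change at the aromatic nitrogen, 4-methylphenyl giving way to tert-butyl, amounts to a number 0.20 degrees C lower from compound 3 to compound 4 (within the scatter), so on the background of compound 3 the two groups cannot be told apart, although one is a six-membered aromatic ring of 7 heavy atoms and the other has no ring and 4 heavy atoms. The step adds a limited point: compound 3 gives 0 degrees C and compound 4 gives -0.2 degrees C, so neither shows any stabilisation of the target, and the result says nothing about how this position behaves in compounds that do show it, such as compound 1 and compound 2. No measurement at hand offers an explanation for this result.

As far as these compounds go, what remains open is whether tert-butyl on this aromatic nitrogen would keep the higher numbers if it were paired with the 4-fluorophenyl of compound 1 rather than with the aryl group shared by compound 3 and compound 4. From the compounds shown here alone, it is equally open whether a different group at this position, such as a methyl, a pyridine ring or a longer chain ending in an amine, would lift the number on either background.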